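The source may hold more compounds than are shown below. What is called first, only, known or untested is meant among the compounds shown, and "the series" means these compounds.

Compound 1 `Cc1ccc(C(=O)Nc2cc(-c3cnn(C)c3)cc(C(F)(F)F)c2)cc1Nc1cc(-c2cccnc2)ccn1`, in a toxicity assay on SH-SY5Y cells (Homo sapiens) for cytotoxicity, read by MTT assay, with a stated time of 48 h (on this read-out higher numbers stand for weaker inhibition and lower numbers for stronger inhibition), a limit: > 80000 nM.
Compound 2 `Cc1ccc(C(=O)Nc2ccc(CN3CCN(C)CC3)c(C(F)(F)F)c2)cc1Nc1cc(-c2cccnc2)ccn1`, in this assay: 19000 nM.

Compound 1 sits at a limit of this assay, (the limit of > 80000 nM in this assay, at which 1 of the 2 values shown sits). Compound 2 therefore holds the only number shown here.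

Compound 3 `Cc1ccc(C(=O)Nc2ccc(CN3CCN(C)CC3)c(C(F)(F)F)c2)cc1Nc1cc(-c2cncnc2)ccn1` differs from compound 2 in one place, pyrimidin-5-yl in place of pyridin-3-yl on an aromatic carbon. Among the measured compounds shown here, no measured pair shows this change, so the step from compound 2 to compound 3 is expected to stay within the usual scatter, a 1.3-fold higher number from compound 2 to compound 3 (0.12 log units; within the scatter). Compound 3 is estimated at 25000 nM, with a range from 8000 nM to 80000 nM.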

Compound 3, half-maximal inhibitory concentration: 12000 nM
The estimate for compound 3 lay 2.1-fold (0.32 log units) above the measured number; the measured number falls inside the stated range.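

In this assay, the position opposite the ring nitrogen now has its first measured step: pyrimidin-5-yl in place of pyridin-3-yl, a swap that brings a second ring nitrogen, gives a 1.6-fold lower number from compound 2 to compound 3 (0.20 log units; within the scatter). The two compounds therefore cannot be told apart on this read-out, so this position accepts that swap without a step beyond the scatter. No measurement shown here bears on the reason for this result.

Still open, on these data alone, is whether a different kind of group at this position, such as an amine or a carboxylic acid, would give a step beyond the scatter.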